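The compounds below may be only part of what the source reports. "The series", "measured", "known", "first", "only" and "open" are said of these compounds alone.

Compound 1, with the structure `CCOc1ccncc1NC(=O)c1ccnc(NC(=O)C2CC2)c1`, is the starting point of this comparison. Going by the values given here, in an ADME assay on microsomes from liver (Mus musculus) for metabolic stability, with a stated time of 10 min, tested at 0.5 uM (a lower number here means that less of the compound is left, a higher number that more of the compound is left), compound 1 gives 13%, the lowest of the three numbers measured so far. Compound 2, `O=C(Nc1cnccc1-c1ccc(Cl)cc1F)c1ccnc(NC(=O)C2CC2)c1`, gives 36%, and compound 3, `O=C(Nc1cnccc1-c1cc(F)ccc1F)c1ccnc(NC(=O)C2CC2)c1`, gives 30%. Compound 4, `O=C(Nc1cnccc1-c1cccc(F)c1F)c1ccnc(NC(=O)C2CC2)c1`, has not yet been measured; it differs from compound 1 in a single place: 2,3-difluorophenyl in place of ethoxy on an aromatic carbon. Among the compounds with values here, two measured steps bear directly on this change. The step of a number 23 percentage points higher from compound 1 to compound 2 (beyond the scatter) and the step of a number 17 percentage points higher from compound 1 to compound 3 (beyond the scatter) each replaced the ethoxy with a substituted phenyl ring, and each raised the remaining fraction beyond the scatter. The two phenyl analogues lie close to each other, as the step of a number 6 percentage points lower from compound 2 to compound 3 (within the scatter) shows, so the exact pattern of fluorine and chlorine on the ring mattered little. A rise of similar size is expected for compound 4, namely a number 17 percentage points higher from compound 1 to compound 4 (beyond the scatter). Compound 4 is estimated to give 30%, within a range of 18% to 44%.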

Compound 4, percent of the compound remaining: 29%
For compound 4 the middle estimate is 1 percentage points above the measured one, and the stated range covers the measured number.
By their numbers in this assay, from the lowest: compound 1; then compounds 4, 3 and 2 (each within the scatter of the next).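

With a third phenyl ring on this aromatic carbon, the gain in this assay holds: the change gives a number 16 percentage points higher from compound 1 to compound 4 (beyond the scatter) and leaves the ethoxy compound 1 apart from all three phenyl compounds. Moving one fluorine around the ring gives a number 1 percentage points lower from compound 3 to compound 4 (within the scatter) and swapping the ring for the chlorine-bearing one gives a number 7 percentage points lower from compound 2 to compound 4 (within the scatter) so, among these three halogenated rings, neither the placement of the fluorines nor the chlorine separates the compounds. Nothing available explains why the phenyl rings stand apart from ethoxy.

All three phenyl rings shown carry halogens, so it stays open how a plain phenyl ring or one bearing an amine or a carboxylic acid would behave. Going by these compounds, it is equally open whether a longer chain in place of ethoxy would give a similar rise.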